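The compounds below may be only part of what the source reports. "The series", "measured", "known", "first", "only" and "open" are said of these compounds alone.

Of the compounds shown here, three built on one shared core have been measured in an assay on CHO cells for displacement of a labelled ligand from D(4) dopamine receptor (Homo sapiens), read by radioligand binding; on this read-out higher numbers stand for weaker inhibition and lower numbers for stronger inhibition. Compound 1 `COc1ccccc1N1CCN(CCCNC(=O)/N=N/c2ccc(F)cc2)CC1` gives 20 nM. Compound 2 `COc1ccccc1N1CCN(CCNC(=O)NN(Cc2ccccc2)c2ccc(F)cc2)CC1` gives 9 nM in this assay. Compound 3 `COc1ccccc1N1CCN(CCCNC(=O)NN(Cc2cccc(F)c2)c2ccc(F)cc2)CC1` gives 3.8 nM in this assay, the lowest of the three numbers; its gaps to compound 2 and to compound 1 both lie beyond the usual scatter, so compound 3 stands as the strongest inhibitor among those measured so far. Compound 4 `COc1ccccc1N1CCN(CCCNC(=O)NN(Cc2ccc(C#N)cc2)c2ccc(F)cc2)CC1` has not yet been measured; it differs from compound 3 in one place: 4-cyanophenyl in place of 3-fluorophenyl on a saturated chain carbon bound to a nitrogen on an aromatic ring. For the measured compounds named here, no pair of measured compounds shows this change on its own, so the expectation rests on compound 3 alone. The step of a 1.6-fold higher number from compound 3 to compound 4 (0.20 log units; within the scatter) is expected to be small, if anything toward a slightly higher number. For compound 4 the expected value in this assay is 6 nM, within a range from 2 nM to 18 nM.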

Compound 4, inhibition constant: 15 nM
Compound 4: middle estimate off by 2.5-fold (0.40 log units), on the low side; the range from low to high includes it.
By their numbers in this assay, from the lowest: compound 3; then compounds 2, 4 and 1 (each within the scatter of the next, the first and the last beyond it).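

The group at this position does matter: in this assay, replacing 3-fluorophenyl with 4-cyanophenyl on a saturated chain carbon bound to a nitrogen on an aromatic ring gives a 3.9-fold higher number from compound 3 to compound 4 (0.60 log units; beyond the scatter) and thus a modest loss of binding strength. For the compounds shown here, this is the first single change read at this place. Nothing available explains the loss.

The swap alters both the ring substituent and its ring position, and these two changes cannot be told apart here. A 4-fluorobenzyl or 3-cyanobenzyl group would change only one of them.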